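This account rests on a few compounds, and the source may have more. Where it says the series, first, only, none or still open, it means among the compounds named here.

Measured compounds:
compound 1, `O=C(NCc1ccc(Cl)cc1Cl)[C@@H]1CCC(=O)N1c1cccs1`, with 0.025 h in an ADME assay on microsomes from liver (Homo sapiens) for metabolic stability, read by HPLC, with a stated time of 60 min, tested at 0.2 mg/mL; on this read-out lower numbers stand for a shorter-lived compound and higher numbers for a longer-lived compound
compound 2, `O=C(NCc1ccc(Cl)cc1Cl)[C@@H]1CCC(=O)N1c1ccco1`, with 0.0867 h in this assay

Compound 2 gives the highest of the two numbers in this assay; its nearest neighbour is compound 1, and the step of a 3.5-fold higher number from compound 1 to compound 2 (0.54 log units; beyond the scatter) lies beyond the scatter. The step to compound 3, `O=C(NCc1ccc(Cl)cc1Cl)[C@@H]1CCC(=O)N1c1nccs1`, is 1,3-thiazol-2-yl in place of furan-2-yl on an amide-type nitrogen in a ring. Within the data shown here, the only measured step, from compound 1 to compound 2, bears on it loosely, since it also exchanged one five-membered aromatic ring for another on the same nitrogen and was modest in size. Among the measured compounds shown here, no measured step involves 1,3-thiazol-2-yl, so the direction is uncertain. Compound 3 is therefore expected to show at most a modest change, a 1.1-fold lower number from compound 2 to compound 3 (0.03 log units; within the scatter), with an estimated 0.08 h in this assay, within a range of 0.03 h to 0.25 h.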

Compound 3, half-life: 0.125 h
Estimate against measurement, compound 3: 1.6-fold (0.19 log units) below; low and high end bracket the measured number.
By their numbers in this assay, from the lowest: compound 1; then compounds 2 and 3 (each within the scatter of the next).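

The step of a 1.4-fold higher number from compound 2 to compound 3 (0.16 log units; within the scatter) shows that at this position, on an amide-type nitrogen in a ring, the change from furan-2-yl to 1,3-thiazol-2-yl, with its second ring hetero atom, does not separate the two compounds. The step of a 5.0-fold higher number from compound 1 to compound 3 (0.70 log units; beyond the scatter) shows that 1,3-thiazol-2-yl, like furan-2-yl, stands clear of thiophen-2-yl, which gives the lowest number of the three. No measurement offered here accounts for these differences. Still open, on these data alone, is how a pyridin-2-yl ring or an open alkyl chain on that nitrogen would read in this assay and whether any such group would lift the half-life further.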